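The source may hold more compounds than are shown below. What is called first, only, known or untested is meant among the compounds shown, and "the series" means these compounds.

Measured so far:
compound 1 `CCn1c(C(=O)N(CCC#N)CCC#N)ccc1C(CC)(CC)c1ccc(OCCC(O)(CC)CC)c(C)c1`: 46300 nM
compound 2 `CCOc1ccc(NC(=O)c2ccc(C(CC)(CC)c3ccc(OCCC(O)(CC)CC)c(C)c3)n2CC)cc1`: > 50000 nM
compound 3 `CCC(C)C(CO)NC(=O)c1ccc(C(CC)(CC)c2ccc(OCCC(O)(CC)CC)c(C)c2)n1CC`: > 50000 nM

All three were tested in a functional assay on HepG2 cells (Homo sapiens) for antiproliferative activity, read by MTT assay, with a stated time of 48 h; on this read-out higher numbers stand for weaker inhibition and lower numbers for stronger inhibition. Compound 1 alone gives a number. Compound 2 gives only a limit, > 50000 nM. Compound 3 also gives only a limit, > 50000 nM. This is the limit of > 50000 nM in this assay, at which 2 of the 3 values shown sit.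

Compound 4 `CCn1c(C(=O)NC(C)CO)ccc1C(CC)(CC)c1ccc(OCCC(O)(CC)CC)c(C)c1` differs from compound 3 in one place: methyl in place of sec-butyl on a saturated chain carbon bound to an amide-type nitrogen and a saturated chain carbon. Going by the values given here, the steps that bear on this change are an at least 1.0-fold higher number from compound 1 to compound 2 (0.03 log units; that floor lies within the scatter) and an at least 1.0-fold higher number from compound 1 to compound 3 (0.03 log units; that floor lies within the scatter), both changing the group on the same carbonyl carbon. A third, a step that the two limits leave unreadable from compound 2 to compound 3, gives no size. Among the compounds with values here, no measured step is readable as beyond the scatter, so none is expected here. The expected step is a number no higher from compound 3 to compound 4 (the limit leaves the size open). The estimate for compound 4 is 50000 nM, with an expected range of 25000 nM to 100000 nM.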

Compound 4, half-maximal inhibitory concentration: 43100 nM
Compound 4: middle estimate off by 1.2-fold (0.06 log units), on the high side, within the range that was stated.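

In this assay compound 4 gives a number where compound 3 gave only a limit, yet the steps, an at least 1.1-fold lower number from compound 3 to compound 4 (0.06 log units; that floor lies within the scatter) and an at least 1.1-fold lower number from compound 2 to compound 4 (0.06 log units; that floor lies within the scatter), are floors within the scatter, so methyl in place of sec-butyl shows no readable gain. Going by these compounds alone, the one step between two numbers, a 1.1-fold lower number from compound 1 to compound 4 (0.03 log units; within the scatter), likewise does not separate the two groups on the carbonyl carbon. The true size of the steps from compound 2 and compound 3 cannot be read because their values stop at a limit: the limit of > 50000 nM in this assay, at which 2 of the 4 values shown sit.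

The compounds shown leave open whether any group on this amide nitrogen moves the number beyond the scatter. An amine or a carboxylic acid in place of the hydroxymethyl of 1-(hydroxymethyl)ethyl would be one such test.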